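The compounds below may be only part of what the source reports. "The series", "measured", "known", "first", "only" and "open" are said of these compounds alone.

In a functional assay (muscle tissue) with Cavia porcellus as the target (a higher number here means that more compound is needed for the effect, a lower number that less compound is needed), compound 1 `COC(=O)C1=C(C)N=C(C)/C(=C(\O)OC)C1c1cccc(Cl)c1Cl` gives 19.1 nM. Going by the values given here, of the two compounds measured so far it carries the highest number, yet compound 2 `COC(=O)C1=C(C)N=C(C)/C(=C(/O)OC)C1c1cccc(Cl)c1` gives 15.9 nM in this assay, and the two values lie within the scatter of each other. Compound 3 `COC(=O)C1=C(C)N=C(C)/C(=C(\O)OC)C1c1cccc(C#N)c1` is not yet measured. It differs from compound 1 in one place: 3-cyanophenyl in place of 2,3-dichlorophenyl on a saturated ring carbon. Among the compounds with values here, no measured pair shows this change, so its size is open. The step is expected to be a modest rise, a 2.1-fold higher number from compound 1 to compound 3 (0.32 log units; beyond the scatter), only a little beyond the scatter. Compound 3 is therefore estimated at about 40 nM, with a likely range from 12 nM to 150 nM.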

Compound 3, half-maximal effective concentration: 34.7 nM
Compound 3: middle estimate off by 1.2-fold (0.06 log units), on the high side; low and high end bracket the measured number.
By their numbers in this assay, from the lowest: compounds 2, 1 and 3 (each within the scatter of the next, the first and the last beyond it).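

Putting 3-cyanophenyl in place of 2,3-dichlorophenyl on this saturated ring carbon gives a 1.8-fold higher number from compound 1 to compound 3 (0.26 log units; within the scatter) in this assay, so the change cannot be told apart from the scatter. This position therefore tolerates a nitrile on the phenyl ring with no chlorine present, although the entering group adds a hydrogen-bond acceptor that the leaving group lacks. Nothing available explains this result. Going by these compounds, whether a phenyl ring bearing an amine or a carboxylic acid would fare the same stays open. So does replacing the aromatic ring with a longer alkyl chain.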